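Ethoxy in Place of Hydrogen on Two Different Cores

The source may report more compounds than this note shows. Statements on the series, on what has been measured and on what is new or still open speak of the compounds shown alone.

The measured compounds, all in a functional assay on P388 cells (Mus musculus) for cytotoxicity, read by MTT assay, with a stated time of 72 h; a higher number here means a weaker inhibitor, a lower number a stronger inhibitor:

compound 1, `COc1ccc(S(=O)(=O)Nc2cccc3[nH]nc(Cl)c23)cc1`, gives 500 nM
compound 2, `CCOc1ccc(NS(=O)(=O)c2ccc(OC)cc2)c2c(Cl)n[nH]c12`, gives 580 nM
compound 3, `C=CCn1cc2ccc(NS(=O)(=O)c3ccc(C)cc3)cc2n1`, gives 4410 nM

Compound 1 and compound 2 share one core and differ in a single place: ethoxy in place of hydrogen on an aromatic carbon. That change produced a 1.2-fold higher number from compound 1 to compound 2 (0.06 log units; within the scatter), so the two compounds are not distinguishable in this assay. Compound 3 sits on a different core; the difference between the two cores is not broken down here. Its number is the highest of the three, and its distance from both compound 1 and compound 2 lies beyond the scatter.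

Compound 4, `C=CCn1cc2ccc(NS(=O)(=O)c3ccc(C)cc3)c(OCC)c2n1`, has not yet been measured. It is related to compound 3 by the same kind of change: ethoxy in place of hydrogen on an aromatic carbon. The surroundings of the place differ between the two pairs: from compound 1 to compound 2 the ethoxy enters para to a large group, whereas from compound 3 to compound 4 it enters ortho to a large group. Because the earlier step of a 1.2-fold higher number from compound 1 to compound 2 (0.06 log units; within the scatter) stayed within the scatter, the step from compound 3 to compound 4 is expected to be small as well: a 1.1-fold higher number from compound 3 to compound 4 (0.05 log units; within the scatter). Compound 4 is therefore estimated at 5000 nM in this assay, with an expected range from 2300 nM to 11000 nM. Going by the values given here, only two examples of this change are available, so the expectation rests on a single measured step.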

Compound 4, half-maximal inhibitory concentration: 68900 nM
Estimate against measurement, compound 4: 14-fold (1.14 log units) below; the whole stated range lies below it.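

In this assay, ethoxy in place of hydrogen on an aromatic carbon produced a large step on the core of compound 3, a 16-fold higher number from compound 3 to compound 4 (1.19 log units; beyond the scatter), so this change cannot be treated as neutral throughout the series. Set beside the earlier step, the result shows that the same change did not carry from one core to the other with the same size: the same change on two cores in this assay, a 1.2-fold higher number (0.06 log units; within the scatter) from compound 1 to compound 2 and a 16-fold higher number (1.19 log units; beyond the scatter) from compound 3 to compound 4, 13-fold (1.13 log units) apart, beyond the scatter of two such steps. It does not show what sets the two steps apart, since the pairs differ both in their core and in the surroundings of the place, with the ethoxy of compound 4 standing ortho to a large group, and a single step on each core cannot separate these two differences or give a rule for any further core.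

The compounds shown leave open whether the large step belongs to ethoxy itself or would also appear with methoxy, a longer chain such as propoxy, or an amine at the same place on the core of compound 3. They also leave open whether ethoxy on another aromatic carbon of that core would give a step closer to the one seen on the core of compound 1.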